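The source may report more compounds than this note shows. Statements on the series, on what has been measured and on what is new or still open speak of the compounds shown alone.

Compound 1 (`O=C(NC[C@H](NS(=O)(=O)c1ccccc1)C(=O)O)c1ccc(N2CCC[C@H](NC3=NCCCN3)C2)cc1F`): 290 nM
Compound 2 (`O=C(NC[C@H](NS(=O)(=O)c1ccc(O)cc1)C(=O)O)c1ccc(N2CCC(NC3=NCCCN3)CC2)c(F)c1`): 230 nM

Both values come from a functional assay on a cell-free system (Platelet, plasma, Homo sapiens) for inhibition (a higher number here means a weaker inhibitor, a lower number a stronger inhibitor), and place compound 2 within the scatter of compound 1, so the two cannot be ranked. Compound 3 (`O=C(O)c1ccc(S(=O)(=O)N[C@@H](CNC(=O)c2ccc(N3CCC(NC4=NCCCN4)CC3)c(F)c2)C(=O)O)cc1`) carries carboxy in place of hydroxy on an aromatic carbon, para to a large group (carboxy in place of hydroxy on an aromatic carbon). Going by the values given here, no measured pair shows this change, so no step beyond the scatter is expected in this assay, in either direction. For compound 3 the estimated value is 250 nM, within an expected range of 80 nM to 800 nM. The estimated step is a 1.1-fold higher number from compound 2 to compound 3 (0.04 log units; within the scatter).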

Compound 3, half-maximal inhibitory concentration: 930 nM
For compound 3 the middle estimate is 3.7-fold (0.57 log units) below the measured one; measured number above the stated range.
By their numbers in this assay, from the lowest: compounds 2 and 1 (each within the scatter of the next); then compound 3.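

Swapping 4-hydroxyphenyl for 4-carboxyphenyl on the sulfonyl gives the only step that can be read in this assay, and it is a loss: a 4.0-fold higher number from compound 2 to compound 3 (0.61 log units; beyond the scatter). Going by these compounds alone, since compound 1 differs from compound 2 in more than one place, this is the first evidence that the group at this position changes the number. Nothing available explains the step.

As far as these compounds go, whether an amine or a methoxy group here would behave like hydroxy or like carboxy remains open. So does whether a longer chain ending in a carboxylic acid would bring the number back down.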